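Chloro to methoxy: one small swap on a growth inhibitor

The source may hold more compounds than are shown below. What is called first, only, known or untested is meant among the compounds shown, and "the series" means these compounds.

In a functional assay on MDA-MB-231 cells (Homo sapiens) for inhibition (on this read-out lower numbers stand for stronger inhibition of growth and higher numbers for weaker inhibition of growth), compound 1 `Cc1cc(C)c2sc(NC(=O)c3ccc(C#N)cc3)nc2c1` gives 290 nM. Compound 2 `Clc1cccc(-n2cc(CNc3ccc(-c4nc5ccccc5s4)cc3)nn2)c1`, with a very different structure, gives 200 nM. These two numbers lie within the usual scatter of repeated measurements, so this assay cannot separate the two compounds, and compound 2 stands level with compound 1.

Compound 3 `COc1cccc(-n2cc(CNc3ccc(-c4nc5ccccc5s4)cc3)nn2)c1` is compound 2 with a single alteration: 3-chlorophenyl becomes 3-methoxyphenyl, which puts methoxy in place of chloro on an aromatic carbon. The rest of the molecule stays the same.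

Among the compounds with values here, no two measured compounds here differ in just one place, so the data offer no direct guide to what this swap does. The estimate therefore starts from compound 2 at 200 nM and stays close to it. The estimated step of a 1.3-fold higher number from compound 2 to compound 3 (0.11 log units; within the scatter) is small, leaning slightly toward weaker inhibition of growth, and is not expected to go beyond the scatter. For compound 3 the estimated value is 260 nM, with an expected range from 90 nM to 800 nM.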

Compound 3, concentration for 50% growth inhibition: 200 nM
Beside the measured number, compound 3's estimate is 1.3-fold (0.11 log units) above it; the range from low to high includes it.
By their numbers in this assay, from the lowest: compounds 2, 3 and 1 (each within the scatter of the next).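

The swap of 3-chlorophenyl for 3-methoxyphenyl gives no change at the digits printed from compound 2 to compound 3 (within the scatter) in this assay and is the only direct reading of a one-place change among these compounds. On this aromatic carbon, meta to a large group, a single chlorine atom can therefore give way to methoxy, which has two heavy atoms and one hydrogen-bond acceptor, with no change in growth inhibition that this read-out can detect. The data contain no separate measurement that could explain why the two groups read alike, so this result describes the outcome of the swap and not its cause.

Chloro and methoxy are only two groups, so it remains open whether an amine, a carboxylic acid or a longer chain such as butoxy on the same aromatic carbon would also leave the number level or would move it beyond the scatter. A single matched pair also leaves open whether the same swap would read the same way at another place on this ring or on a different core, such as that of compound 1.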